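From methoxycarbonyl to propoxycarbonyl on compound 3

A few compounds are considered here, and "the series" means these few. Any claim that something is new, unique, unknown or untested is made for them only; others in the source may bear on it.

Measured in a functional assay on HT-29 cells (Homo sapiens) for antiproliferative activity, read by MTT assay, with a stated time of 48 h; a lower number here means a stronger inhibitor of growth, a higher number a weaker inhibitor of growth:
- compound 1 `CCCOC(=O)N1N=C(c2ccccc2)CC1c1cc(OC)c(OC)c(OC)c1` gives > 10000 nM, a limit of the assay
- compound 2 `COC(=O)N1N=C(c2cccc(OC)c2)CC1c1cc(OC)c(OC)c(OC)c1` gives 1300 nM
- compound 3 `COC(=O)N1N=C(c2ccc(OC)cc2)CC1c1cc(OC)c(OC)c(OC)c1` gives 2550 nM

Only two of these results are true numbers, and they lie within the scatter of each other, with a 2.0-fold higher number from compound 2 to compound 3 (0.29 log units; within the scatter). Compound 3 therefore stands level with compound 2 in this assay.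

Compound 4 `CCCOC(=O)N1N=C(c2ccc(OC)cc2)CC1c1cc(OC)c(OC)c(OC)c1` keeps the 4-methoxyphenyl group of compound 3 and exchanges methoxycarbonyl for propoxycarbonyl: ethyl in place of hydrogen on a saturated chain carbon bound to an oxygen next to a carbonyl group. For the measured compounds named here, no measured step isolates this change. Going by the values given here, the one step available, a 2.0-fold higher number from compound 2 to compound 3 (0.29 log units; within the scatter), concerns the methoxyphenyl group and gives no size for a change in the chain.

Among the compounds with values here, compound 1 is the only measured compound with propoxycarbonyl, and it reports only a limit, > 10000 nM. Within the data shown here, it also has a plain phenyl group, and no compound separates these two differences. The evidence is therefore weak, but it points towards weaker growth inhibition with the longer chain. The expected change is a 2.2-fold higher number from compound 3 to compound 4 (0.33 log units; beyond the scatter), and this estimate is uncertain in size. The assay may also report only a limit. Compound 4 is expected at 5500 nM, with an estimated range from 2000 nM to 10000 nM.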

Compound 4, concentration for 50% growth inhibition: 12700 nM
Compound 4: middle estimate off by 2.3-fold (0.36 log units), on the low side; the whole stated range lies below it.
By their numbers in this assay, from the lowest: compounds 2 and 3 (each within the scatter of the next); then compound 4.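

In this assay, the exchange of methoxycarbonyl for propoxycarbonyl now has a readable size, with the 4-methoxyphenyl group held the same on both sides (a 5.0-fold higher number from compound 3 to compound 4 (0.70 log units; beyond the scatter)). For the compounds shown here, the longer chain gives weaker growth inhibition in this one pair, and this step lies beyond the scatter, unlike the only earlier step (a 2.0-fold higher number from compound 2 to compound 3 (0.29 log units; within the scatter)), which concerned the place of the methoxy group on the phenyl ring and lay within it. Compound 1 reports only a limit, so its step to compound 4, methoxy in place of hydrogen on an aromatic carbon, cannot be read and the methoxy group's part stays unsized: the limit of > 10000 nM in this assay, at which 1 of the 4 values shown sits.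

On these data alone, a single pair carries the chain change, so it remains open whether propoxycarbonyl has a step of similar size alongside the 3-methoxyphenyl group of compound 2. The compounds shown also leave open how the number moves with ethoxycarbonyl, which would stand between the two chains, or with a longer chain such as butoxycarbonyl.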